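The compounds below may be only part of what the source reports. "The series", "measured", "known", "first", "only" and "open" are said of these compounds alone.

Two compounds sharing one core were tested in a functional assay on CHO-K1 cells for antagonist activity at melanin-concentrating hormone receptor 1 (Homo sapiens), read by inositol phosphate accumulation, with stated times of 10 min and 45 min; a higher number here means a weaker inhibitor, a lower number a stronger inhibitor. Compound 1 `Cc1nc(NCCCNS(C)(=O)=O)nc2ccc(NC(=O)/C=C/c3ccc(OC(F)(F)F)cc3)cc12` gives 32 nM in this assay. Compound 2 `Cc1nc(N2CCC(N3C(=O)CCC3=O)CC2)nc2ccc(NC(=O)/C=C/c3ccc(OC(F)(F)F)cc3)cc12` gives 35 nM in this assay. Compound 2 thus shows the higher of the two numbers, yet its gap to compound 1 lies within the scatter, so the two cannot be told apart on these data.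

Compound 3 `Cc1nc(N2CCC(N3CCCC3=O)CC2)nc2ccc(NC(=O)/C=C/c3ccc(OC(F)(F)F)cc3)cc12` has not yet been measured. It differs from compound 2 by 2-oxopyrrolidin-1-yl in place of 2,5-dioxopyrrolidin-1-yl on a saturated ring carbon. For the measured compounds named here, no step between measured compounds touches this part of the molecule, so nothing measured bears directly on the change. The step from compound 2 is expected to be small, most likely none beyond the scatter, with no clear direction. Compound 3 is expected to give about 35 nM in this assay, within a range from 12 nM to 100 nM. The expected step is no change at the digits printed from compound 2 to compound 3 (within the scatter).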

Compound 3, half-maximal inhibitory concentration: 12 nM
Beside the measured number, compound 3's estimate is 2.9-fold (0.46 log units) above it; the measured number falls inside the stated range.
By their numbers in this assay, from the lowest: compound 3; then compounds 1 and 2 (each within the scatter of the next).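

In this assay, the group on the saturated ring carbon, three ring bonds from the ring nitrogen, turns out to matter: 2-oxopyrrolidin-1-yl in place of 2,5-dioxopyrrolidin-1-yl, a change of one carbonyl, gives a 2.9-fold lower number from compound 2 to compound 3 (0.46 log units; beyond the scatter). The earlier pair had shown no separation, since compound 1 and compound 2 lay within the scatter of each other, whereas 4-(2-oxopyrrolidin-1-yl)piperidin-1-yl in place of (3-(methanesulfonamido)propyl)amino on the aromatic carbon now gives a 2.7-fold lower number from compound 1 to compound 3 (0.43 log units; beyond the scatter). Nothing among the data shown accounts for either step.

As far as these compounds go, it remains open how a plain pyrrolidin-1-yl group, with no carbonyl at all, would read on that saturated ring carbon, and so whether the remaining carbonyl is needed. A 2-oxopiperidin-1-yl group there would show whether the five-membered ring size matters.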